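A Methoxy for Chloro Swap on a Shared Core

The compounds below may be only part of what the source reports. "The series", "measured", "known", "first", "only" and "open" are said of these compounds alone.

Of the compounds shown here, three sharing one core have been tested in a functional assay on SMMC-7721 cells (Homo sapiens) for cytotoxicity, read by MTT assay, with a stated time of 72 h; a higher number here means a weaker inhibitor, a lower number a stronger inhibitor. There, compound 1 `CCC(C)=C1C(=O)N(c2ccc(Cl)cc2)N(c2ccc(Cl)cc2)C1=O` gives 49200 nM, compound 2 `O=C1C(=Cc2ccc(Cl)cc2)C(=O)N(c2ccc(Cl)cc2)N1c1ccc(Cl)cc1` gives 30900 nM and compound 3 `COc1cc(C=C2C(=O)N(c3ccc(Cl)cc3)N(c3ccc(Cl)cc3)C2=O)cc(OC)c1OC` gives 29500 nM. Compound 2 lies within the usual scatter of both others, so these three cannot be ranked. Compound 4 `COc1ccc(C=C2C(=O)N(c3ccc(Cl)cc3)N(c3ccc(Cl)cc3)C2=O)cc1` differs from compound 2 in one place: methoxy in place of chloro on an aromatic carbon. Among the compounds with values here, no measured pair shows this swap alone, but compound 3 also carries methoxy groups and gives 29500 nM. The expected change in this assay is therefore none beyond the scatter, an estimated step of a 1.1-fold higher number from compound 2 to compound 4 (0.03 log units; within the scatter). Compound 4 is expected near 33000 nM, with an estimated range of 15000 nM to 70000 nM.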

Compound 4, half-maximal inhibitory concentration: > 128000 nM
Compound 4: a limit, no number (the forecaster's own chance of this, stated with the estimate: 8%); at least 3.8-fold (0.58 log units) between middle value and limit.
By their numbers in this assay, from the lowest: compounds 3, 2 and 1 (each within the scatter of the next). At a limit, above all of these: compound 4.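

Replacing 4-chlorophenyl with 4-methoxyphenyl gives an at least 4.1-fold higher number from compound 2 to compound 4 (0.61 log units; beyond the scatter), so this position, para to a large group, does respond to what sits on it. Compounds 1, 2 and 3 could not show this, as their values all lie within the scatter of one another. Compound 4 gives no number in this assay, only a limit: the limit of > 128000 nM in this assay, at which 1 of the 4 values shown sits.

On these data alone, how far the true value of compound 4 lies past that limit remains open. So does whether an amine or a carboxylic acid at this position would behave more like chloro or like methoxy.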